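The compounds below may be only part of what the source reports. "The series", "measured", "known", "first", "only" and "open" are said of these compounds alone.

Compounds measured in a functional assay on CHO cells for agonist activity at Free fatty acid receptor 1 (Homo sapiens); a higher number here means that more compound is needed for the effect, a lower number that less compound is needed:
compound 1 `Cc1nc(-c2ccc(C(F)(F)F)cc2)sc1CNc1ccc(CCCC(=O)O)cc1` — < 10000 nM, a limit of the assay rather than a number
compound 2 `Cc1nc(-c2ccc(C(F)(F)F)cc2)sc1CNc1ccc(/C=C/C(=O)O)cc1` — 36.3 nM
compound 3 `Cc1nc(-c2ccc(C(F)(F)F)cc2)sc1CNc1ccc(C(C)CC(=O)O)cc1` — 58.9 nM

Compound 3 gives the higher of the two numbers in this assay; its step to compound 2, a 1.6-fold higher number from compound 2 to compound 3 (0.21 log units; within the scatter), lies within the scatter, so the two cannot be ordered. For compound 1 only a limit is known (the limit of < 10000 nM in this assay, at which 1 of the 3 values shown sits), which leaves a step that the limit leaves unreadable from compound 1 to compound 2 and a step that the limit leaves unreadable from compound 1 to compound 3 unreadable.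

Compound 4 `Cc1nc(-c2ccc(C(F)(F)F)cc2)sc1CNc1ccc([C@H]2C[C@@H]2C(N)=O)cc1` differs from compound 3 by 2-carbamoylcyclopropyl in place of 1-(carboxymethyl)ethyl on an aromatic carbon. Within the data shown here, no measured step bears directly on this change: every measured compound carries a carboxy group, and the only readable step, a 1.6-fold higher number from compound 2 to compound 3 (0.21 log units; within the scatter), exchanges one carboxy-bearing chain for another and stays within the scatter. From the compounds shown here alone, the replacement of the carboxy group by a carbamoyl group on a cyclopropyl ring is untested, so the expected step of a 6.8-fold higher number from compound 3 to compound 4 (0.83 log units; beyond the scatter) is an estimate set with wide uncertainty, and it is possible that compound 4 will turn out to sit at a limit of the assay rather than give a number. Compound 4 is estimated at 400 nM in this assay, with a range from 60 nM to 5000 nM.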

Compound 4, half-maximal effective concentration: 4.47 nM
For compound 4 the middle estimate is 89-fold (1.95 log units) above the measured one; measured number below the stated range.
By their numbers in this assay, from the lowest: compound 4; then compounds 2 and 3 (each within the scatter of the next).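

Among these compounds, on an aromatic carbon para to a large group, the earlier compounds all carried a carboxy group and could not be ordered among themselves; in this assay, 2-carbamoylcyclopropyl now gives a 13-fold lower number from compound 3 to compound 4 (1.12 log units; beyond the scatter) and an 8.1-fold lower number from compound 2 to compound 4 (0.91 log units; beyond the scatter). Among the compounds shown, a carboxy group is therefore not needed at this place for a low number, and the carbamoyl-bearing ring beats both readable carboxy-bearing chains. Compound 1 has only a limit, so every step from it, including the one to compound 4, cannot be read: the limit of < 10000 nM in this assay, at which 1 of the 4 values shown sits.

From the compounds shown here alone, the change brings in the cyclopropyl ring and the carbamoyl group together, so their separate shares stay open; a 2-carboxycyclopropyl group or an open-chain 2-carbamoylethyl group would divide them. Going by these compounds, how the mirror-image and the other ring stereoisomers of 2-carbamoylcyclopropyl compare also stays open.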